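Expected Potency of Compound 4 from a Repeated Ring Swap

The source may hold more compounds than are shown below. What is called first, only, known or untested is meant among the compounds shown, and "the series" means these compounds.

Compound 1 `Cc1noc(C)c1-c1cnc(N)c(Oc2ccc(C(=O)Nc3ccccc3Cl)cc2)n1` — > 100000 nM
Compound 2 `Cn1cc(-c2cnc(N)c(Oc3ccc(C(=O)Nc4ccccc4Cl)cc3)n2)cn1` — 66900 nM
Compound 3 `Cc1noc(C)c1-c1cnc(N)c(Sc2ccc(C(=O)Nc3ccc(Cl)cc3)cc2)n1` — 45200 nM

Of the compounds shown here, three have been measured in a functional assay on HepG2 cells (Homo sapiens) for inhibition, read by MTT assay, with a stated time of 72 h; on this read-out lower numbers stand for stronger inhibition and higher numbers for weaker inhibition. For compound 1 the value > 100000 nM is a limit of the assay and not a number (the limit of > 100000 nM in this assay, at which 1 of the 3 values shown sits). Compound 2 gives 66900 nM, and compound 3 gives 45200 nM; these two lie within the scatter of each other. The one-place change 1-methyl-1H-pyrazol-4-yl in place of 3,5-dimethyl-1,2-oxazol-4-yl on an aromatic carbon is measured as an at least 1.4-fold lower number from compound 1 to compound 2 (0.17 log units; that floor lies within the scatter). How the core of compound 3 differs from that of compound 1 is not broken down here. Compound 4 `Cn1cc(-c2cnc(N)c(Sc3ccc(C(=O)Nc4ccc(Cl)cc4)cc3)n2)cn1` is not yet measured and carries the same change on the core of compound 3: 1-methyl-1H-pyrazol-4-yl in place of 3,5-dimethyl-1,2-oxazol-4-yl on an aromatic carbon. Since the earlier step of an at least 1.4-fold lower number from compound 1 to compound 2 (0.17 log units; that floor lies within the scatter) reached only a floor within the scatter, the expected step here is a 1.3-fold lower number from compound 3 to compound 4 (0.11 log units; within the scatter), of similar size. Compound 4 is therefore estimated at 35000 nM, between 12000 nM and 100000 nM.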

Compound 4, half-maximal inhibitory concentration: > 100000 nM
Compound 4 ended at the assay's limit; the forecaster's own chance of this, stated with the estimate: 15%; middle value at least 2.8-fold (0.45 log units) from the limit.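

On the core of compound 3, putting 1-methyl-1H-pyrazol-4-yl in place of 3,5-dimethyl-1,2-oxazol-4-yl gives, in this assay, an at least 2.2-fold higher number from compound 3 to compound 4 (0.34 log units; beyond the scatter). The change therefore did not carry over unchanged from one core to the other: the same change on two cores in this assay, an at least 1.4-fold lower number (0.17 log units; that floor lies within the scatter) from compound 1 to compound 2 and an at least 2.2-fold higher number (0.34 log units; beyond the scatter) from compound 3 to compound 4, at least 3.3-fold (0.51 log units) apart, beyond the scatter of two such steps. Compound 1 and compound 4 each stand at a limit of the assay and not at a number, so the full size of neither step is known: the limit of > 100000 nM in this assay, at which 2 of the 4 values shown sit.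

The compounds shown leave open which difference between the core of compound 1 and the core of compound 3 matters for this change. Also open, going by these compounds, is how a phenyl or a morpholine in place of the five-membered ring would read in this assay.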